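The source may report more compounds than this note shows. Statements on the series, on what has been measured and on what is new or still open speak of the compounds shown alone.

In a functional assay on T47D cells (Homo sapiens) for cytotoxicity, read by MTT assay, with a stated time of 3 h (a lower number here means a stronger inhibitor, a higher number a weaker inhibitor), compound 1 `O=C(CN1CCN(c2cc(=O)n(-c3ccccc3)c3ccccc23)CC1)Nc1nc(-c2ccc(Cl)cc2)cs1` gives 30200 nM, and compound 2 `O=c1cc(N2CCNCC2)c2cc(F)ccc2[nH]1` gives 37700 nM; the two numbers lie within the scatter of each other, so neither stands apart from the other on this evidence. Compound 3 `COc1ccc(-c2csc(NC(=O)CN3CCN(c4cc(=O)n(-c5ccccc5)c5ccccc45)CC3)n2)cc1` keeps the core of compound 1 and differs in one place: methoxy in place of chloro on an aromatic carbon. Within the data shown here, no measured pair shows this change, so its effect is unknown from the data. Expected is a 1.0-fold lower number from compound 1 to compound 3 (0.00 log units; within the scatter), a step no larger than the scatter, in no particular direction. Compound 3 is therefore estimated at 30000 nM, with a range from 12000 nM to 75000 nM.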

Compound 3, half-maximal inhibitory concentration: 8110 nM
For compound 3 the middle estimate is 3.7-fold (0.57 log units) above the measured one; the whole stated range lies above it.
By their numbers in this assay, from the lowest: compound 3; then compounds 1 and 2 (each within the scatter of the next).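

In this assay, placing methoxy instead of chloro on the aromatic carbon para to a large group gives a 3.7-fold lower number from compound 1 to compound 3 (0.57 log units; beyond the scatter), which shows that the number responds to what sits at this position. Among these compounds, it is the first one-place difference available here, and though modest, it lies beyond the scatter. No measurement at hand bears on why this step arises.

From the compounds shown here alone, whether a hydroxy group, an amine or a longer alkoxy chain at this carbon would give a similar number remains open. So does whether the same change would hold on another core.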